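From Amino to Propoxy on a Shared Core

The source may hold more compounds than are shown below. What is called first, only, known or untested is meant among the compounds shown, and "the series" means these compounds.

Of the compounds shown here, three have so far been tested in a functional assay (spleen, spleen) for activation, with Mus musculus as the target; on this read-out lower numbers stand for an effect already at smaller amounts and higher numbers for an effect only at larger amounts of compound. Compound 1 `Nc1ncnc2c1nc(O)n2Cc1ccc(Cl)cc1` gives 10 uM in this assay. Compound 2 `Nc1ncnc2c1nc(O)n2C1CCCC1` reaches only the limit of this assay, > 10 uM, so no number is known for it. Compound 3 `Nc1nc(N)c2nc(O)n(Cc3ccccc3)c2n1` gives 10 uM, the same number as compound 1 and within the usual scatter, so no difference between the two can be claimed. One of the three results is a limit rather than a number, (the limit of > 10 uM in this assay, at which 1 of the 3 values shown sits). Within the data shown here, no two measured compounds differ in only one place, so no measured step is available to lean on.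

Compound 4 `CCCOc1nc(N)c2nc(O)n(Cc3ccccc3)c2n1` differs from compound 3 by propoxy in place of amino on an aromatic carbon. Without a measured step for such a change, the expectation rests on compound 3 and on the size of the change alone. Compound 4 is expected to give 3 uM, between 0.3 uM and 10 uM. This means an expected 3.3-fold lower number from compound 3 to compound 4 (0.52 log units; beyond the scatter), a modest shift toward an effect at smaller amounts, not far beyond the scatter.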

Compound 4, minimum effective concentration: 0.01 uM
Estimate against measurement, compound 4: 300-fold (2.48 log units) above, outside the stated range (below it).
By their numbers in this assay, from the lowest: compound 4; then compounds 1 and 3 (each within the scatter of the next).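

In this assay, among these compounds, propoxy in place of amino on the aromatic carbon between two ring nitrogen atoms gives a 1000-fold lower number from compound 3 to compound 4 (3.00 log units; beyond the scatter), the first measured step on this core, and it shows that the read-out can respond very strongly to what sits at this position. The change puts 4 heavy atoms and 0 hydrogen-bond donors where amino had 1 heavy atom and 1 hydrogen-bond donor, and a single step cannot tell which of these differences matters. Nothing measured here accounts for the size of this step.

Still open, going by these compounds, is whether the oxygen link or the length of the chain carries the effect, a question that methoxy, butoxy or a propylamine chain at this carbon could answer. Also open, on these data alone, is how far the chain can grow before the effect fades.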